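Nitrophenyl hydrazones of a glucoside: shifting the nitro group

A few compounds are considered here, and "the series" means these few. Any claim that something is new, unique, unknown or untested is made for them only; others in the source may bear on it.

In a functional assay on MDA-MB-231 cells (Homo sapiens) for inhibition, read by MTT assay, with a stated time of 24 h, tested at 100 uM (on this read-out higher numbers stand for more inhibition at the one concentration tested (going by the name of the read-out) and lower numbers for less inhibition), compound 1 `CC(C)/C=N/NC(=O)c1ccc(O[C@@H]2O[C@H](CO)[C@@H](O)[C@H](O)[C@H]2O)cc1` gives 1.7%. Compound 2 `O=C(N/N=C/c1ccc([N+](=O)[O-])cc1)c1ccc(O[C@@H]2O[C@H](CO)[C@@H](O)[C@H](O)[C@H]2O)cc1`, in which a 4-nitrophenyl replaces the isopropyl on a carbon with a double bond to nitrogen, gives 7.12% in this assay . Compound 2 carries the larger of the two numbers, but a number 5.4 percentage points higher from compound 1 to compound 2 (within the scatter), so the two compounds cannot be told apart on these data.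

Compound 3 `O=C(N/N=C/c1cccc([N+](=O)[O-])c1)c1ccc(O[C@@H]2O[C@H](CO)[C@@H](O)[C@H](O)[C@H]2O)cc1` differs from compound 2 only in this way: 3-nitrophenyl in place of 4-nitrophenyl on a carbon with a double bond to nitrogen. Within the data shown here, no measured pair changes where the nitro group sits on the phenyl ring, so the only step that bears on this one is the swap of isopropyl for 4-nitrophenyl, which itself stayed within the scatter. With both measured numbers small, the step from compound 2 to compound 3 is expected to be a number 0.1 percentage points lower from compound 2 to compound 3 (within the scatter), that is, no change beyond the scatter. Compound 3 is therefore estimated at 7%, with a range from 0% to 25%.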

Compound 3, a percentage reported as inhibition, at one concentration (the size of the read-out at that concentration, not a potency): 6.23%
Compound 3: the middle estimate sits 0.8 percentage points above what was measured; the range from low to high includes it.
By their numbers in this assay, from the lowest: compounds 1, 3 and 2 (each within the scatter of the next).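

Moving the nitro group on the phenyl ring is now tested directly: in this assay the change gives a number 0.9 percentage points lower from compound 2 to compound 3 (within the scatter), so 3-nitrophenyl and 4-nitrophenyl on the carbon with a double bond to nitrogen cannot be told apart. Replacing isopropyl with the 3-nitrophenyl group gives a number 4.5 percentage points higher from compound 1 to compound 3 (within the scatter), so at this place neither nitrophenyl group can be separated from isopropyl. No measurement is available that could explain these results.

These compounds therefore give no sign of which change at this place, if any, would raise the inhibition beyond the scatter. Going by these compounds, it remains open whether an amine, a carboxylic acid or a longer carbon chain on this carbon would give a number clearly different from those of compound 1, compound 2 and compound 3.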